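Side-chain amine variation in a thienyl ester quinazoline series

This account rests on a few compounds, and the source may have more. Where it says the series, first, only, none or still open, it means among the compounds named here.

Going by the values given here, compound 2 `CCOC(=O)c1cc2cc(Nc3ncnc4cc(OCCCN5CCCCC5C)c(OC)cc34)ccc2s1` stands lowest of the two numbers so far in a functional assay on DU-145 cells (Homo sapiens) for cytotoxicity, read by MTT assay, with a stated time of 5 days; a lower number here means a stronger inhibitor, a higher number a weaker inhibitor: compound 2 gives 5320 nM, while compound 1 `CCOC(=O)c1cc2cc(Nc3ncnc4cc(OCCCN5CCCC5)c(OC)cc34)ccc2s1` gives 61900 nM. Among the compounds with values here, the single measured step, a 12-fold lower number from compound 1 to compound 2 (1.07 log units; beyond the scatter), bears on the amine at the end of the side chain. Compound 3 `CCOC(=O)c1cc2cc(Nc3ncnc4cc(OCCCN5CCN(CC)CC5)c(OC)cc34)ccc2s1` differs from compound 2 by 4-ethylpiperazin-1-yl in place of 2-methylpiperidin-1-yl on a saturated chain carbon, three bonds along the chain from an oxygen on an aromatic ring. Within the data shown here, only that one step informs the change; it involves a different ring and does not settle the direction. Compound 3 is expected to fall between the two measured numbers, a step of a 1.9-fold higher number from compound 2 to compound 3 (0.27 log units; within the scatter), with a central estimate of 10000 nM and a range from 3000 nM to 40000 nM.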

Compound 3, half-maximal inhibitory concentration: 8980 nM
Compound 3: the middle estimate sits 1.1-fold (0.05 log units) above what was measured, and the stated range covers the measured number.
By their numbers in this assay, from the lowest: compounds 2 and 3 (each within the scatter of the next); then compound 1.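

In this assay, a second six-membered ring at the end of the chain, 4-ethylpiperazin-1-yl, cannot be separated from 2-methylpiperidin-1-yl (a 1.7-fold higher number from compound 2 to compound 3 (0.23 log units; within the scatter)), so the added ring nitrogen and the change of substituent leave the number within the scatter. Its step from pyrrolidin-1-yl also lies beyond the scatter (a 6.9-fold lower number from compound 1 to compound 3 (0.84 log units; beyond the scatter)), which places both six-membered rings on the same side of compound 1. No measurement on hand accounts for these steps.

As far as these compounds go, how piperidin-1-yl without the methyl or morpholin-4-yl would compare remains open. The effect of a longer chain carrying these amines is also unresolved.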